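The compounds below may be only part of what the source reports. "The series", "measured", "known", "first", "only" and "open" are said of these compounds alone.

Compound 1 `CCN(c1ccc(C#N)c(Cl)c1)c1cc(-c2cccs2)ccc1C`: "not determined" (no result reported) in a functional assay on VCaP cells (Homo sapiens) for antiproliferative activity, read by CCK-8 assay, with a stated time of 6 days; on this read-out lower numbers stand for stronger inhibition and higher numbers for weaker inhibition
Compound 2 `CCN(c1ccc(C#N)c(Cl)c1)c1cc(-c2ccoc2)ccc1C`: 4010 nM
Compound 3 `CCN(c1ccc(C#N)c(Cl)c1)c1cc(-c2ccccc2)ccc1C`: > 30000 nM, which is a limit of the assay and not a number

Compound 3 therefore stands at the edge of what this assay reports, as one of the values that sit at the limit of > 30000 nM in this assay, at which 1 of the 3 values shown sits. Within the data shown here, only one measured step bears on its neighbourhood: an at least 7.4-fold higher number from compound 2 to compound 3 (0.87 log units; beyond the scatter), in which phenyl took the place of furan-3-yl on an aromatic carbon, a change of at least modest size beyond the scatter. Compound 4 `CCN(c1ccc(C#N)c(Cl)c1)c1cc(-c2cccnc2)ccc1C` is the next compound, and it differs from compound 3 in one place: pyridin-3-yl in place of phenyl on an aromatic carbon. Since the only heteroaromatic ring measured so far gave a lower number than phenyl, a heteroaromatic ring entering at the same position leads one to expect a lower number for compound 4 as well, the expected step being an at least 2.5-fold lower number from compound 3 to compound 4 (0.39 log units; beyond the scatter). Compound 4 is accordingly estimated at 12000 nM, with a range from 3000 nM to 40000 nM, and it is expected that the assay may again report only a limit.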

Compound 4, half-maximal inhibitory concentration: 1270 nM
For compound 4 the middle estimate is 9.4-fold (0.98 log units) above the measured one; the whole stated range lies above it.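

Pyridin-3-yl in place of phenyl gives an at least 23-fold lower number from compound 3 to compound 4 (1.37 log units; beyond the scatter) in this assay and so shows that this position, meta to a large group and para to a methyl group, responds strongly to a change within a six-membered aromatic ring. The same ring also compares well with the five-membered furan-3-yl, with a 3.2-fold lower number from compound 2 to compound 4 (0.50 log units; beyond the scatter) at this position, so a six-membered ring here does not by itself go with the weak result of compound 3. The first of these steps is a bound and not a measured size, since compound 3 stands at a limit of the assay: the limit of > 30000 nM in this assay, at which 1 of the 4 values shown sits.

The compounds shown leave open how pyridin-2-yl, pyridin-4-yl or a pyridine ring carrying an amine would compare at this position. Compound 1, with its thiophen-2-yl ring, offers no comparison, since it has no reported result.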